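This account rests on a few compounds, and the source may have more. Where it says the series, first, only, none or still open, it means among the compounds named here.

Measured so far:
- compound 1 `O=C(O)c1ccc(CCCCCC(=O)N2CCOC2=O)cc1`: > 20000 nM
- compound 2 `Nc1ccc(CCCCCC(=O)N2CCOC2=O)cc1`: 15700 nM
- compound 3 `O=C1OCCN1C(=O)c1ccc(Oc2ccc(O)cc2)cc1`: > 20000 nM

In an assay on HEK293 cells for inhibition of N-acylethanolamine-hydrolyzing acid amidase (Rattus norvegicus), read by LC-MS, with a stated time of 30 min (on this read-out lower numbers stand for stronger inhibition and higher numbers for weaker inhibition), compound 3 has no number of its own, only a limit, and it is not alone in that: the limit of > 20000 nM in this assay, at which 2 of the 3 values shown sit. Going by the values given here, compound 2 is the one measured compound with a real number, and the step of an at least 1.2-fold lower number from compound 1 to compound 2 (0.10 log units; that floor lies within the scatter), amino in place of carboxy on an aromatic carbon, has its floor within the scatter, so it shows no movement that can be relied upon.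

Compound 4 `CCCCOc1ccc(C(=O)N2CCOC2=O)cc1` differs from compound 3 by butyl in place of 4-hydroxyphenyl on an oxygen on an aromatic ring. Among the compounds with values here, none of the measured steps touches that position or that kind of exchange; the one step that exists concerns a substituent on the aromatic carbon and is itself within the scatter. Within the data shown here, there is therefore no measured step from which a direction for compound 4 in this assay can be read, and the most that the data support is an expectation that compound 4 stays near where compound 3 sits, that is an expected step of a number no higher from compound 3 to compound 4 (the limit leaves the size open). Compound 4 is accordingly estimated at 20000 nM, with a range from 8000 nM to 50000 nM, and a good chance that only a limit is reported again.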

Compound 4, half-maximal inhibitory concentration: 1340 nM
Estimate against measurement, compound 4: 15-fold (1.17 log units) above; measured number below the stated range.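

In this assay, the exchange of 4-hydroxyphenyl for butyl on an oxygen on an aromatic ring gives an at least 14-fold lower number from compound 3 to compound 4 (1.17 log units; beyond the scatter). Unlike the earlier step, whose floor lay within the scatter, this one shows that the group on this oxygen can move the read-out by a reliable margin, and that the open butyl chain gives a real number where the ring-bearing group gives none. Compound 3 has only a limit, so the step gives a floor and not a full size, and that limit is shared: the limit of > 20000 nM in this assay, at which 2 of the 4 values shown sit.

The compounds shown leave open whether a longer chain or a branched chain on the same oxygen would move the number further. They also leave open whether a plain phenyl group there would stand nearer compound 3 or compound 4.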